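The compounds below may be only part of what the source reports. "The series", "measured", "known", "first", "only" and "open" are said of these compounds alone.

Measured compounds:
- compound 1 `CSc1coc(C(=O)CCCCCCc2ccccc2)n1` gives 29 nM
- compound 2 `O=C(CCCCCCc1ccccc1)c1nc(-c2ccccn2)co1` gives 1.9 nM
- compound 3 `O=C(CCCCCCc1ccccc1)c1nc(-c2ccccc2)co1` gives 65 nM

In an assay on isolated protein for inhibition of Fatty-acid amide hydrolase 1 (Rattus norvegicus) (a lower number here means a stronger inhibitor, a higher number a weaker inhibitor), compound 1 gives 29 nM. Among the three measured compounds, compound 1 stands second highest: compound 3 sits nearest, and compound 2 furthest. The step of a 2.2-fold higher number from compound 1 to compound 3 (0.35 log units; beyond the scatter) is modest, while the step of a 15-fold lower number from compound 1 to compound 2 (1.18 log units; beyond the scatter) is large; the step of a 34-fold higher number from compound 2 to compound 3 (1.53 log units; beyond the scatter) is large as well.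

Compound 4 `CNC(=O)c1coc(C(=O)CCCCCCc2ccccc2)n1` has not yet been measured in this assay. It differs from compound 1 in one place: methylcarbamoyl in place of methylsulfanyl on an aromatic carbon. Both measured steps from compound 1 bear on this change, since each swaps the methylsulfanyl group for another group on the same aromatic carbon. The swap to pyridin-2-yl gave the large step of a 15-fold lower number from compound 1 to compound 2 (1.18 log units; beyond the scatter); the swap to phenyl gave the modest step of a 2.2-fold higher number from compound 1 to compound 3 (0.35 log units; beyond the scatter). Within the data shown here, no measured compound carries a methylcarbamoyl group, so its effect is uncertain. Given that one replacement at this position lowered the number strongly and the other raised it only modestly, a lower number is expected for compound 4, of moderate size, a 2.9-fold lower number from compound 1 to compound 4 (0.46 log units; beyond the scatter). The estimate for compound 4 in this assay is 10 nM, with a range from 2 nM to 50 nM.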

Compound 4, inhibition constant: 1.8 nM
Compound 4: middle estimate off by 5.6-fold (0.74 log units), on the high side; measured number outside the range, below it.
By their numbers in this assay, from the lowest: compounds 4 and 2 (each within the scatter of the next); then compound 1; then compound 3.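

At this position, on the aromatic carbon next to the ring nitrogen, a low number in this assay does not depend on an aromatic ring, which compound 2 alone could not show: the open-chain methylcarbamoyl group gives a large step (a 16-fold lower number from compound 1 to compound 4 (1.21 log units; beyond the scatter)). Compound 4 and compound 2 cannot be told apart (a 1.1-fold lower number from compound 2 to compound 4 (0.02 log units; within the scatter)), so two groups that share no ring type or size reach the same level, even though methylcarbamoyl has a hydrogen-bond donor and pyridin-2-yl has none. Phenyl is the group that goes against any simple reading, as replacing it with methylcarbamoyl gives the largest of the new steps (a 36-fold lower number from compound 3 to compound 4 (1.56 log units; beyond the scatter)), so neither group size nor the presence of a ring sorts these four compounds.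

No measurement shown here explains why these groups differ. As far as these compounds go, it remains open whether the amide hydrogen matters, which a dimethylcarbamoyl group would address, and whether a primary amide, a methyl ester, a carboxylic acid or a longer chain on the amide nitrogen would give a similarly low number.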